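Removing the Triazole Methyl in a Kinase Inhibition Series

This account rests on a few compounds, and the source may have more. Where it says the series, first, only, none or still open, it means among the compounds named here.

Compound 1 `Cn1nc(O)c(C(=O)Nc2cc(C(F)(F)F)cc(C(F)(F)F)c2)n1` gives 9.1% in an assay on isolated protein for inhibition of mitogen-activated protein kinase kinase kinase 14 (Homo sapiens), read by ADP-Glo, with a stated time of 60 min, tested at 100 uM, in the presence of a further agent that is not named here (a lower number here means less inhibition, a higher number more inhibition at the concentration tested (going by the name of the read-out)), the second highest of three numbers. Compound 3 `Cn1nnc(O)c1C(=O)Nc1cc(C(F)(F)F)cc(C(F)(F)F)c1` gives 12.1% there, and the step of a number 3 percentage points higher from compound 1 to compound 3 (within the scatter) lies within the scatter. Compound 2 `O=C(Nc1cccc(C(F)(F)F)c1)c1nsnc1O`, built on a different core, gives -1.1%, a gap below compound 1 that is beyond the scatter.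

Compound 4 `O=C(Nc1cc(C(F)(F)F)cc(C(F)(F)F)c1)c1n[nH]nc1O` differs from compound 1 by hydrogen in place of methyl on an aromatic nitrogen. Within the data shown here, the only step measured on this core, from compound 1 to compound 3, swapped the whole ring attachment and stayed within the scatter, and no measured step removes a methyl from an aromatic nitrogen. The expected step is therefore a number 0.1 percentage points lower from compound 1 to compound 4 (within the scatter), nothing beyond the scatter. Compound 4 is estimated at 9%, within -2% to 20%.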

Compound 4, a percentage reported as inhibition, at one concentration (the size of the read-out at that concentration, not a potency): -9.5%
Estimate against measurement, compound 4: 18.5 percentage points above; measured number below the stated range.
By their numbers in this assay, from the lowest: compounds 4 and 2 (each within the scatter of the next); then compounds 1 and 3 (each within the scatter of the next).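

Among these compounds, replacing the methyl with hydrogen on this aromatic nitrogen gives a number 18.6 percentage points lower from compound 1 to compound 4 (beyond the scatter) in this assay, whereas the one earlier step between methylated compounds stayed within the scatter. The comparison with the other methylated compound points the same way, with a number 21.6 percentage points lower from compound 3 to compound 4 (beyond the scatter) also beyond the scatter, so at these two compounds the presence of a methyl on the ring goes with the higher number. Nothing measured here explains this difference. As far as these compounds go, whether an ethyl group or a longer chain on this nitrogen would raise the number further stays open, as does the effect of an amine in place of the hydroxy group.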